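Nitrophenyl in Place of Methylphenyl on a Shared Core

This account rests on a few compounds, and the source may have more. Where it says the series, first, only, none or still open, it means among the compounds named here.

Compound 1 `Cc1ccccc1N1C(=O)/C(=C/c2ccc(OCC(=O)Nc3ccc(C(=O)O)cc3)cc2)SC1=S`: > 10000 nM
Compound 2 `O=C(O)c1ccc(COc2cccc(/C=C3\SC(=S)N(c4ccc([N+](=O)[O-])cc4)C3=O)c2)cc1`: > 10000 nM

In an assay on isolated protein for inhibition of Apoptosis regulator Bcl-2 (Homo sapiens), read by fluorescence polarization (a lower number here means a stronger inhibitor, a higher number a weaker inhibitor), compound 1 gives > 10000 nM, which is a limit of the assay and not a number. Compound 2 also gives a limit, > 10000 nM. Both results sit at the limit of > 10000 nM in this assay, at which 2 of the 2 values shown sit. Compound 3 `O=C(COc1ccc(/C=C2\SC(=S)N(c3ccc([N+](=O)[O-])cc3)C2=O)cc1)Nc1ccc(C(=O)O)cc1` has not been measured; it differs from compound 1 by 4-nitrophenyl in place of 2-methylphenyl on an amide-type nitrogen in a ring. Going by the values given here, no step between measured compounds is known, and compound 2, which also bears 4-nitrophenyl, gives > 10000 nM, so no change beyond the scatter is expected. The expected step is a step that the limit leaves unreadable from compound 1 to compound 3. Compound 3 is expected to give 15000 nM, somewhere between 5000 nM and 50000 nM.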

Compound 3, inhibition constant: > 10000 nM
Compound 3: only a limit was reported; the forecaster's own chance of this, stated with the estimate: 80%; the middle value does not contradict the limit.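

No step from compound 1 to compound 3 can be read, since each result is a limit of the assay and not a number: the limit of > 10000 nM in this assay, at which 3 of the 3 values shown sit.

The compounds shown leave open how strongly any of them binds, and whether 4-nitrophenyl in place of 2-methylphenyl changes that at all.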